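Halogen steps from compound 1

The compounds below may be only part of what the source reports. "The series", "measured", "known", "first", "only" and "open" are said of these compounds alone.

Measured in a functional assay on the whole organism with Rattus norvegicus as the target; on this read-out lower numbers stand for an effect already at smaller amounts and higher numbers for an effect only at larger amounts of compound:
- compound 1 `O=C(O)c1cc(-c2ccccc2)ccc1O`: 54 mg/kg
- compound 2 `O=C(O)c1cc(-c2ccc(F)cc2)ccc1O`: 14 mg/kg
- compound 3 `O=C(O)c1cc(-c2ccc(Cl)cc2)ccc1O`: 24 mg/kg

Compound 1 has the highest number of the three, and both halogen compounds lie beyond the scatter from it. The next compound to consider is compound 4 `O=C(O)c1cc(-c2ccccc2F)ccc1O`, which differs from compound 1 as follows: fluoro in place of hydrogen on an aromatic carbon. This is fluoro in place of hydrogen on an aromatic carbon, ortho to a large group.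

Going by the values given here, two measured steps bear on this change, a 3.9-fold lower number from compound 1 to compound 2 (0.59 log units; beyond the scatter) and a 2.3-fold lower number from compound 1 to compound 3 (0.35 log units; beyond the scatter). Both are modest and point the same way. The remaining step, a 1.7-fold higher number from compound 2 to compound 3 (0.23 log units; within the scatter), lies within the scatter, so the choice of halogen is not resolved by these data. Among the compounds with values here, the data also hold no compound with a halogen ortho to a large group, so the transfer from compound 2 is uncertain. A modest step is therefore expected in this assay, smaller than the fluoro step already seen, and toward a lower number: a 2.2-fold lower number from compound 1 to compound 4 (0.33 log units; beyond the scatter). For compound 4 the estimated value is 25 mg/kg, with an expected range of 10 mg/kg to 60 mg/kg.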

Compound 4, dose for half-maximal effect: 20 mg/kg
For compound 4 the middle estimate is 1.3-fold (0.10 log units) above the measured one; the range from low to high includes it.
By their numbers in this assay, from the lowest: compounds 2, 4 and 3 (each within the scatter of the next); then compound 1.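

In this assay, fluoro in place of hydrogen on an aromatic carbon ortho to a large group also gives a lower number (a 2.7-fold lower number from compound 1 to compound 4 (0.43 log units; beyond the scatter)), and this step lies beyond the scatter. The lowering from compound 1 is therefore not tied to the single ring place shared by compound 2 and compound 3, and it now holds for all three halogen compounds shown. Nothing at hand explains this result or accounts for how the halogen steps act at either place.

Still open, from the compounds shown here alone, is what chloro does ortho to a large group, since the only halogen seen there is fluoro in compound 4. Equally open, going by these compounds, is whether a group other than a halogen at this place, such as methyl, methoxy or an amine, would also give a lower number than compound 1.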